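Working notes: the step from compound 1 to compound 4

This account rests on a few compounds, and the source may have more. Where it says the series, first, only, none or still open, it means among the compounds named here.

Going by the values given here, compound 1 `CC(C)(C)Sc1c(CC(C)(C)C(=O)O)n(Cc2ccc(Cl)cc2)c2ccc(CCc3ccc4ccccc4n3)cc12` gives 4 nM in a functional assay for inhibition, with Homo sapiens as the target (a lower number here means a stronger inhibitor, a higher number a weaker inhibitor), the lowest of the three numbers so far, although each gap to the other two lies within the scatter. Compound 3 `CC(C)(C)Sc1c(CC(C)(C)C(=O)O)n(Cc2ccc(Cl)cc2)c2ccc(OCc3ccncc3)cc12` gives 6 nM. The step of a 1.5-fold higher number from compound 1 to compound 3 (0.18 log units; within the scatter) stays within the scatter. Compound 2 `COc1ccc2nc(COc3ccc4c(c3)c(SC(C)(C)C)c(CC(C)(C)C(=O)O)n4Cc3ccc(Cl)cc3)sc2c1` gives 8 nM; its gap to compound 1 is likewise within the scatter. The step of a 1.3-fold lower number from compound 2 to compound 3 (0.12 log units; within the scatter) shows that exchanging the group on a saturated chain carbon bound to an oxygen on an aromatic ring also moves the number little.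

Compound 4 `CC(C)c1csc(COc2ccc3c(c2)c(SC(C)(C)C)c(CC(C)(C)C(=O)O)n3Cc2ccc(Cl)cc2)n1` is not yet measured. Relative to compound 1 it carries a group of 10 heavy atoms (7 carbon, 1 nitrogen, 1 oxygen, 1 sulfur; one five-membered aromatic ring with 2 hetero atoms) in place of a group of 12 heavy atoms (11 carbon, 1 nitrogen; one six-membered aromatic ring of carbon only, one six-membered aromatic ring with 1 hetero atom), on an aromatic carbon. Among the compounds with values here, two measured steps bear on this: a 1.5-fold higher number from compound 1 to compound 3 (0.18 log units; within the scatter) covers removal of the 2-(quinolin-2-yl)ethyl group in favour of an oxygen-bound group, and a 1.3-fold lower number from compound 2 to compound 3 (0.12 log units; within the scatter) covers variation of the aromatic group on that chain; both lie within the scatter. No step beyond the scatter is therefore expected in this assay in either direction. For compound 4 the expected value is 6 nM, with a range of 2.5 nM to 15 nM. The expected step is a 1.5-fold higher number from compound 1 to compound 4 (0.18 log units; within the scatter).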

Compound 4, half-maximal inhibitory concentration: 3 nM
Beside the measured number, compound 4's estimate is 2.0-fold (0.30 log units) above it; the range from low to high includes it.
By their numbers in this assay, from the lowest: compounds 4, 1, 3 and 2 (each within the scatter of the next, the first and the last beyond it).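

In this assay, going by these compounds alone, placing 4-isopropyl-1,3-thiazol-2-yl on the saturated chain carbon bound to an oxygen, in place of 6-methoxy-1,3-benzothiazol-2-yl, gives a 2.7-fold lower number from compound 2 to compound 4 (0.43 log units; beyond the scatter) as the first step at this position beyond the scatter, though a modest one. The exchange for pyridin-4-yl gives a 2.0-fold lower number from compound 3 to compound 4 (0.30 log units; within the scatter) and the exchange of the whole group for 2-(quinolin-2-yl)ethyl gives a 1.3-fold lower number from compound 1 to compound 4 (0.12 log units; within the scatter) and, both being within the scatter, neither separates these groups. No measurement available here accounts for the modest step.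

The compounds shown leave open how a methoxy group or an aminoethyl chain on this aromatic carbon would compare with these ring-bearing groups. Also open, from the compounds shown here alone, is whether the step from compound 2 rests on the isopropyl group, the methoxy group or the fused ring, as these change together.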